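The source may report more compounds than this note shows. Statements on the series, on what has been measured and on what is new or still open speak of the compounds shown alone.

Of the compounds shown here, two from this series have so far been tested in a functional assay on SNU1 cells (Homo sapiens) for cytotoxicity, read by CellTiter-Glo, with a stated time of 5 days; on this read-out lower numbers stand for stronger inhibition and higher numbers for weaker inhibition. Compound 1, `CC(C)=CCCC(=O)[C@]1(/C=C/C(C)C)C[C@H](CC=C(C)C)C(C)(C)[C@@H](C(=O)c2ccccc2)C1=O`, gives only a limit of the assay rather than a number, namely > 10000 nM. Compound 2, `CC(C)=CC[C@@H]1C[C@H](CC=C(C)C)C(C)(C)[C@H](C(=O)C(C)C)C1=O`, likewise gives only a limit in this assay, > 10000 nM. Both results therefore sit at the limit of > 10000 nM in this assay, at which 2 of the 2 values shown sit, so nothing can yet be said about how compound 2 ranks against compound 1; the two readings cannot be ordered, and neither compound shows measurable cytotoxicity within the tested range.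

The next compound, compound 3, has the structure `CC(C)=CC[C@@H]1C[C@H](CC=C(C)C)C(C)(C)[C@@H](C(=O)C(C)C)C1=O`. Its relation to compound 2 is the two compounds have the same atoms and bonds and differ only in configuration as drawn: 1 of 3 stereo elements differ; a stereocentre at a saturated ring carbon is drawn R in compound 2 and S in compound 3. Going by the values given here, no step between two measured compounds is available to calibrate what such a change in configuration does in this assay.

Given that compound 2 reaches only the limit > 10000 nM, compound 3 is expected to behave much the same, with any step that the limit leaves unreadable from compound 2 to compound 3 expected to stay within the usual scatter. The estimate for compound 3 in this assay is 15000 nM, within a range from 5000 nM to 50000 nM, and it is expected that the assay will most likely again report only a limit.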

Compound 3, half-maximal inhibitory concentration: > 10000 nM
Compound 3: only a limit was reported; the forecaster's own chance of this, stated with the estimate: 85%; the middle value does not contradict the limit.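

No step can be read between compound 2 and compound 3, since both results are limits of the assay rather than numbers: the limit of > 10000 nM in this assay, at which 3 of the 3 values shown sit.

The compounds shown leave open what this change in configuration at a saturated ring carbon does in this assay, and which features of the series, if any, go with measurable cytotoxicity.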